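Trading 3,4-Dichlorophenyl for 4-Iodophenyl in a Receptor Agonist Series

This account rests on a few compounds, and the source may have more. Where it says the series, first, only, none or still open, it means among the compounds named here.

In an assay on cells for activation of probable G-protein coupled receptor 34 (Mus musculus), with a stated time of 1 h (on this read-out higher numbers stand for larger maximal responses and lower numbers for smaller maximal responses), compound 3 `N[C@@H](COP(=O)(O)OCCCOC(=O)CCc1ccccc1OCc1cccc(Oc2ccc(Cl)c(Cl)c2)c1)C(=O)O` gives 0.71, the highest of the three measured compounds. Compound 1 `N[C@@H](COP(=O)(O)OCCCOC(=O)CCc1ccccc1OCc1cccc(OC2CCCCC2)c1)C(=O)O` gives 0.11 and compound 2 `Cc1cccc(Oc2cccc(COc3ccccc3CCC(=O)OCCCOP(=O)(O)OC[C@H](N)C(=O)O)c2)c1` gives 0.29. Compound 4 `N[C@@H](COP(=O)(O)OCCCOC(=O)CCc1ccccc1OCc1cccc(Oc2ccc(I)cc2)c1)C(=O)O` differs from compound 3 in one place: 4-iodophenyl in place of 3,4-dichlorophenyl on an oxygen on an aromatic ring. Going by the values given here, the steps that bear on this change are a number 0.60 higher from compound 1 to compound 3 (beyond the scatter) and a number 0.42 higher from compound 2 to compound 3 (beyond the scatter), both reached by placing 3,4-dichlorophenyl on the same oxygen; the smaller step a number 0.18 higher from compound 1 to compound 2 (beyond the scatter) shows that a 3-methylphenyl group gives only part of that gain. Because both large steps a number 0.60 higher from compound 1 to compound 3 (beyond the scatter) and a number 0.42 higher from compound 2 to compound 3 (beyond the scatter) came from introducing 3,4-dichlorophenyl, a moderate fall is expected for compound 4, a number 0.21 lower from compound 3 to compound 4 (beyond the scatter). Compound 4 is therefore estimated at 0.5, within 0.3 to 0.75.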

Compound 4, intrinsic activity: the largest response reached, as a fraction of the reference agonist's: 0.82
The estimate for compound 4 lay 0.32 below the measured number, and the stated range ends below it.
By their numbers in this assay, from the lowest: compound 1; then compound 2; then compound 3; then compound 4.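

On this oxygen, the high maximal response in this assay does not require 3,4-dichlorophenyl: 4-iodophenyl, with a single halogen, goes further, a number 0.11 higher from compound 3 to compound 4 (beyond the scatter). Its gains over the other two groups are larger, a number 0.53 higher from compound 2 to compound 4 (beyond the scatter) and a number 0.71 higher from compound 1 to compound 4 (beyond the scatter), making compound 4 the highest of the four. Nothing available explains why this change raises the response. The compounds shown leave open how 4-bromophenyl or 4-chlorophenyl on this oxygen would compare with 4-iodophenyl, and whether 3-iodophenyl would hold the response.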